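The source may report more compounds than this note shows. Statements on the series, on what has been measured and on what is new or still open speak of the compounds shown alone.

Of the compounds shown here, three sharing one core have been tested in an ADME assay on L02 cells (Homo sapiens) for cytotoxicity, read by MTT assay, with a stated time of 48 h; a higher number here means a weaker inhibitor, a lower number a stronger inhibitor. Compound 1 `O=C1O[C@@H](CO)CN1c1ccc(-n2cc(-c3ccccn3)cn2)c(F)c1` gives 59 ug/mL. Compound 2 `CN(C)S(=O)(=O)NC[C@H]1CN(c2ccc(-n3cc(-c4ccccn4)cn3)c(F)c2)C(=O)O1` gives 158 ug/mL, and compound 3 `COC(=O)NC[C@H]1CN(c2ccc(-n3cc(-c4ccccn4)cn3)c(F)c2)C(=O)O1` gives 71 ug/mL. Compound 1 sits at the low end of these three numbers: its step to compound 3 is a 1.2-fold higher number from compound 1 to compound 3 (0.08 log units; within the scatter), while its step to compound 2 is a 2.7-fold higher number from compound 1 to compound 2 (0.43 log units; beyond the scatter). Compound 4 `O=C1O[C@@H](CNC(=O)C(F)(F)F)CN1c1ccc(-n2cc(-c3ccccn3)cn2)c(F)c1` has not yet been measured; it differs from compound 1 as follows: ((trifluoromethyl)carbonyl)amino in place of hydroxy on a saturated chain carbon bound to a saturated ring carbon. Both measured steps replace the same hydroxy with a larger group, and neither lowered the number: one stayed within the scatter, the other rose modestly. The expected step is therefore of similar kind, a 1.4-fold higher number from compound 1 to compound 4 (0.16 log units; within the scatter). Compound 4 is estimated at 85 ug/mL, with a range of 40 ug/mL to 180 ug/mL.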

Compound 4, half-maximal inhibitory concentration: > 400 ug/mL
Compound 4: only a limit was reported (the forecaster's own chance of this, stated with the estimate: 10%); middle value at least 4.7-fold (0.67 log units) away from the limit.
By their numbers in this assay, from the lowest: compounds 1 and 3 (each within the scatter of the next); then compound 2. At a limit, above all of these: compound 4.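

At this position, on a saturated chain carbon bound to a saturated ring carbon, replacing hydroxy does not always leave the number close to that of compound 1 in this assay (an at least 6.7-fold higher number from compound 1 to compound 4 (0.83 log units; beyond the scatter)). A change on the carbonyl carbon alone, trifluoromethyl in place of methoxy, also moves it far (an at least 5.6-fold higher number from compound 3 to compound 4 (0.75 log units; beyond the scatter)), and the number even exceeds that of the dimethylsulfamoyl compound (an at least 2.5-fold higher number from compound 2 to compound 4 (0.40 log units; beyond the scatter)). The result for compound 4 is a limit, not a number: the limit of > 400 ug/mL in this assay, at which 1 of the 4 values shown sits.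

Going by these compounds, how far compound 4 lies past that limit remains unknown. On these data alone, whether acetylamino, with a plain methyl on the carbonyl carbon, would behave like compound 3 or compound 4 also stays open.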